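A few compounds are considered here, and "the series" means these few. Any claim that something is new, unique, unknown or untested is made for them only; others in the source may bear on it.

Compound 1 `COc1ccc(C2CC(c3ccc(O)cc3)=NN2C(=O)c2cccnc2)cc1C`: 44800 nM
Compound 2 `O=C(c1cccnc1)N1N=C(c2ccc(O)cc2)CC1c1ccc(OCc2ccccc2)cc1`: 11400 nM

In an ADME assay on HepG2 cells (Homo sapiens) for cytotoxicity, read by MTT assay, with a stated time of 7 days (on this read-out lower numbers stand for stronger inhibition and higher numbers for weaker inhibition), compound 1 gives 44800 nM, the highest of the two numbers. Compound 2 gives 11400 nM in this assay, a lower number, and the gap between the two lies beyond the scatter. Compound 3 `CC(C)c1ccccc1C1CC(c2ccc(O)cc2)=NN1C(=O)c1cccnc1` has not yet been measured. It differs from compound 1 in one place: 2-isopropylphenyl in place of 4-methoxy-3-methylphenyl on a saturated ring carbon. Within the data shown here, no measured pair shows a change of this kind, so the step is expected to be small, a 1.3-fold lower number from compound 1 to compound 3 (0.11 log units; within the scatter), and not beyond the scatter in either direction. Compound 3 is therefore estimated at 35000 nM, with a range from 12000 nM to 100000 nM.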

Compound 3, half-maximal inhibitory concentration: 49700 nM
Beside the measured number, compound 3's estimate is 1.4-fold (0.15 log units) below it; low and high end bracket the measured number.
By their numbers in this assay, from the lowest: compound 2; then compounds 1 and 3 (each within the scatter of the next).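

In this assay, putting 2-isopropylphenyl in place of 4-methoxy-3-methylphenyl on this saturated ring carbon gives a 1.1-fold higher number from compound 1 to compound 3 (0.05 log units; within the scatter), so the read-out does not separate these two groups. The leaving group holds a hydrogen-bond acceptor and the entering group holds none, yet the two numbers lie within the scatter. Nothing available here offers an explanation for this result. As far as these compounds go, whether an amine or a carboxylic acid at this position would move the number beyond the scatter remains open.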